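The source may report more compounds than this note shows. Statements on the series, on what has been measured and on what is new or still open speak of the compounds shown alone.

Notes on the series. In a physicochemical assay for solubility, measured as kinetic solubility, with a stated time of 1 h, at pH 7.4 (on this read-out lower numbers stand for lower solubility and higher numbers for higher solubility), compound 1 (`N#CCC(=O)Nc1nc(-c2ccc(Cl)c(Cl)c2)c[nH]1`) gives 14000 nM, compound 2 (`N#CCC(=O)Nc1nsc(-c2ccc(Cl)c(Cl)c2)n1`) gives 69000 nM and compound 3 (`N#CCC(=O)NC1=NN(c2ccc(Cl)c(Cl)c2)CC1`) gives 202000 nM. Compound 3 thus stands highest of the three, beyond the scatter from both of the others. Compound 4 (`O=C(NC1=NN(c2ccc(Cl)c(Cl)c2)CC1)c1cccnn1`) has pyridazin-3-yl in place of cyanomethyl on a carbonyl carbon. Going by the values given here, no measured pair differs in one place only, so the series offers no direct precedent for this change. In this assay a downward step beyond the scatter is expected, starting from the top of the measured range, where compound 3 sits at 202000 nM. The estimated change is a 3.4-fold lower number from compound 3 to compound 4 (0.53 log units; beyond the scatter). The expected value for compound 4 is 60000 nM, with an estimated range from 15000 nM to 180000 nM.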

Compound 4, solubility: 67000 nM
Beside the measured number, compound 4's estimate is 1.1-fold (0.05 log units) below it; the measured number falls inside the stated range.
By their numbers in this assay, from the lowest: compound 1; then compounds 4 and 2 (each within the scatter of the next); then compound 3.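

Working from the carbonyl carbon whose other neighbour is the amide-type nitrogen, the series now has its first one-place reading: in this assay, pyridazin-3-yl in place of cyanomethyl gives a 3.0-fold lower number from compound 3 to compound 4 (0.48 log units; beyond the scatter) at this place. The step is modest, so a six-membered aromatic ring with 2 hetero atoms can stand here without a large fall in the number. Going by these compounds alone, nothing measured so far accounts for the size of this step. Still open, from the compounds shown here alone, is how a simple phenyl ring or a morpholine would read on this carbonyl carbon. Also open, going by these compounds, is whether the same change on the cores of compound 1 and compound 2 gives a similar step.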